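Exchanging the (4-methylphenyl)amino group of compound 2

A few compounds are considered here, and "the series" means these few. Any claim that something is new, unique, unknown or untested is made for them only; others in the source may bear on it.

- Compound 1 `COC(=O)c1ccc(-n2cc(CCCOC(=O)c3ccc(C)cc3)nn2)cc1`: > 100000 nM (a limit)
- Compound 2 `COC(=O)c1ccc(-n2cc(CCCNc3ccc(C)cc3)nn2)cc1`: > 100000 nM (a limit)

In a functional assay on A549 cells (Homo sapiens) for inhibition, read by MTT assay, with a stated time of 72 h (on this read-out lower numbers stand for stronger inhibition and higher numbers for weaker inhibition), compound 2 gives > 100000 nM, which is a limit and not a number. The pair so far offers only (the limit of > 100000 nM in this assay, at which 2 of the 2 values shown sit), so neither compound has a numerical value.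

Compound 3 `COC(=O)c1ccc(-n2cc(CCCOc3ccc(C)cc3)nn2)cc1` carries 4-methylphenoxy in place of (4-methylphenyl)amino on a saturated chain carbon, three bonds along the chain from an aromatic carbon. For the measured compounds named here, no measured step shows what this exchange does in this assay. Since compound 2 stands at > 100000 nM, a limit, no step beyond the scatter is expected, in either direction. The expected step is a number no higher from compound 2 to compound 3 (the limit leaves the size open). Compound 3 is estimated at 100000 nM, with an expected range of 30000 nM to 200000 nM.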

Compound 3, half-maximal inhibitory concentration: > 100000 nM
Compound 3: a limit, no number; the forecaster's own chance of this, stated with the estimate: 70%; the middle value lies on the limit itself.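

In this assay compound 3 gives > 100000 nM as a limit and not a number. The steps from compound 1 and compound 2 to compound 3 therefore cannot be read: the limit of > 100000 nM in this assay, at which 3 of the 3 values shown sit. The compounds shown leave open how any of these three side chains ranks against the others.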